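The source may report more compounds than this note shows. Statements on the series, on what has been measured and on what is new or still open speak of the compounds shown alone.

Measured so far:
- Compound 1 `COc1ccc(/C=N/NC(=O)CNC(=O)c2ccc(F)cc2)c(OCc2ccccc2Cl)c1`: 15700 nM
- Compound 2 `Cc1ccc(C(=O)NCC(=O)N/N=C/c2cccc(OCc3ccccc3Cl)c2)cc1`: 47500 nM
- Compound 3 `Cc1cccc(CSCCNC(=O)CN(c2cccc(C(F)(F)F)c2)S(C)(=O)=O)c1`: 23400 nM

All three were tested in a functional assay on HepG2 cells (Homo sapiens) for inhibition, read by MTT assay, with a stated time of 24 h; a higher number here means a weaker inhibitor, a lower number a stronger inhibitor. Compound 1 has the lowest number of the set, but its value lies within the scatter of that of compound 3. Only compound 2 has a number higher than that of compound 1 by more than the scatter.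

Compound 4 `O=C(CNC(=O)c1ccc(F)cc1)N/N=C/c1ccccc1OCc1ccccc1Cl` keeps the core of compound 1 and carries hydrogen in place of methoxy on an aromatic carbon. Going by the values given here, no pair of measured compounds isolates this change, so the data give no direct guide to its effect. Compound 2 also has no methoxy and gives 47500 nM, but it differs from compound 1 in other places too, so it offers only a weak hint of an upward move. A small rise, not beyond the scatter, is therefore expected, and the estimated step is a 1.4-fold higher number from compound 1 to compound 4 (0.15 log units; within the scatter). For compound 4 the expected value is 22000 nM, with an estimated range from 9000 nM to 55000 nM.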

Compound 4, half-maximal inhibitory concentration: 24900 nM
For compound 4 the middle estimate is 1.1-fold (0.05 log units) below the measured one, within the range that was stated.
By their numbers in this assay, from the lowest: compounds 1, 3, 4 and 2 (each within the scatter of the next, the first and the last beyond it).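

Going by these compounds alone, with compound 4, the methoxy group meta to the (2-chlorobenzyl)oxy group is isolated as a single change for the first time. In this assay, hydrogen in its place gives a 1.6-fold higher number from compound 1 to compound 4 (0.20 log units; within the scatter) and leaves the two compounds within the scatter of each other, so on this core the methoxy group is not shown to be needed for the inhibition read here. No measurement on hand offers an explanation for this small step.

From the compounds shown here alone, the comparison covers only methoxy and hydrogen at this aromatic carbon, so it remains open whether a hydroxyl, an ethoxy group or an amine there would move the number beyond the scatter. Also open, going by these compounds, is whether the same exchange would give a similar step on a core carrying a different group in place of the 4-fluorobenzoyl amide.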